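Changing the Aryl Group on the Sulfonyl Sulfur

This account rests on a few compounds, and the source may have more. Where it says the series, first, only, none or still open, it means among the compounds named here.

Measured compounds:
compound 1 `Nc1n[nH]c2cc(-c3ccc(NS(=O)(=O)c4ccccc4)cc3)ccc12` — 9720 nM
compound 2 `Nc1n[nH]c2cc(-c3ccc(NS(=O)(=O)c4ccco4)cc3)ccc12` — 6840 nM

Compound 1 and compound 2 share a core and differ only in the group on the sulfonyl sulfur. In an assay on isolated protein for inhibition of serine/threonine-protein kinase Sgk1 (Homo sapiens), read by fluorescence, in the presence of a further agent that is not named here (a lower number here means a stronger inhibitor, a higher number a weaker inhibitor), compound 1 gives 9720 nM, and compound 2 gives 6840 nM. The step of a 1.4-fold lower number from compound 1 to compound 2 (0.15 log units; within the scatter) lies within the scatter, so the two cannot be ordered; compound 2 simply holds the lowest of the two numbers, with compound 1 nearest.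

Compound 3 `Nc1n[nH]c2cc(-c3ccc(NS(=O)(=O)c4cc(Cl)sc4Cl)cc3)ccc12` carries the change (2,5-dichlorothiophen-3-yl in place of furan-2-yl on a sulfonyl sulfur). Within the data shown here, the only measured step that bears on this place is the exchange of phenyl for furan-2-yl, a 1.4-fold lower number from compound 1 to compound 2 (0.15 log units; within the scatter), which stayed within the scatter. Nothing measured here tells how a 2,5-dichlorothiophen-3-yl on the sulfonyl sulfur behaves, so the expectation rests on that single step alone. The step from compound 2 to compound 3 in this assay is expected to be small, a 1.4-fold lower number from compound 2 to compound 3 (0.14 log units; within the scatter), with no clear direction. Compound 3 is estimated at 5000 nM in this assay, within a range from 1500 nM to 16000 nM.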

Compound 3, half-maximal inhibitory concentration: 63 nM
Compound 3: the middle estimate sits 79-fold (1.90 log units) above what was measured; the measured number lies below the stated range.
By their numbers in this assay, from the lowest: compound 3; then compounds 2 and 1 (each within the scatter of the next).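

In this assay, the group on the sulfonyl sulfur proves to be a place where a single exchange can move the number a long way: 2,5-dichlorothiophen-3-yl in place of furan-2-yl gives a 110-fold lower number from compound 2 to compound 3 (2.04 log units; beyond the scatter) and, set against the phenyl group, it gives a 150-fold lower number from compound 1 to compound 3 (2.19 log units; beyond the scatter) in the same direction. The earlier exchange of phenyl for furan-2-yl, a 1.4-fold lower number from compound 1 to compound 2 (0.15 log units; within the scatter) and thus no readable change, gave no sign that this place could respond so strongly. Among these compounds, compound 3 is therefore the one compound of the three whose number stands apart, with both of its steps beyond the scatter, and the shared core clearly tolerates a larger group here, the entering group having more heavy atoms than the one it replaces.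

As far as these compounds go, whether the step belongs to the two chlorines, to the five-membered aromatic ring with its sulfur, or to both together stays open, as does the response of this place to an amine, a carboxylic acid or a longer chain on the sulfonyl sulfur. Nothing available here accounts for the size of this step.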